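A few compounds are considered here, and "the series" means these few. Any claim that something is new, unique, unknown or untested is made for them only; others in the source may bear on it.

In a functional assay on Hep 3B2 cells (Homo sapiens) for inhibition, read by MTT assay, with a stated time of 72 h (a lower number here means a stronger inhibitor, a higher number a weaker inhibitor), compound 1 (`CNC(=O)CCCCCCCn1nc(-c2cnc3[nH]ccc3c2)c2c(N)ncnc21`) gives 16300 nM, compound 2 (`Nc1ncnc2c1c(-c1cnc3[nH]ccc3c1)nn2CCCCCCCCC(=O)NO`) gives 8390 nM and compound 3 (`Nc1nc2cc(-c3nn(CCCCC(=O)NO)c4ncnc(N)c34)ccc2o1`) gives 33700 nM. Compound 3 thus holds the highest of the three numbers, beyond the scatter from both others. Compound 4 (`Nc1nc2cc(-c3nn(CCCCCCC(=O)NO)c4ncnc(N)c34)ccc2o1`) keeps the core of compound 3 and differs in the chain: 2-(hydroxycarbamoyl)ethyl in place of hydroxycarbamoyl on a saturated chain carbon, four bonds along the chain from an aromatic nitrogen. The new group, 2-(hydroxycarbamoyl)ethyl, replaces hydroxycarbamoyl on a saturated chain carbon, four bonds along the chain from an aromatic nitrogen.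

Among the compounds with values here, only one measured step bears on this, and only indirectly: a 1.9-fold lower number from compound 1 to compound 2 (0.29 log units; within the scatter). It is a change at the chain end on a different core, and it stays within the scatter. Within the data shown here, no measured pair isolates this change on the core of compound 3. Compound 2 at 8390 nM lies below compound 3 at 33700 nM, but the two differ in more than one place. A moderate fall in the number is therefore expected in this assay, with wide uncertainty. The expected step is a 3.1-fold lower number from compound 3 to compound 4 (0.49 log units; beyond the scatter). Compound 4 is estimated at 11000 nM, with an expected range of 3000 nM to 35000 nM.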

Compound 4, half-maximal inhibitory concentration: 14000 nM
Estimate against measurement, compound 4: 1.3-fold (0.10 log units) below, within the range that was stated.
By their numbers in this assay, from the lowest: compounds 2, 4 and 1 (each within the scatter of the next); then compound 3.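

On the core of compound 3, extending the chain from hydroxycarbamoyl to 2-(hydroxycarbamoyl)ethyl, on a saturated chain carbon, four bonds along the chain from an aromatic nitrogen, has a readable effect: in this assay it gives a 2.4-fold lower number from compound 3 to compound 4 (0.38 log units; beyond the scatter). Within the data shown here, this is the first step to lie beyond the scatter, and it shows that chain length at this position moves the number, though only modestly, while the earlier step at the chain end, on a different core, stayed within the scatter. No measured evidence accounts for the lower number with the longer chain.

As far as these compounds go, it remains open whether a still longer chain on this core would continue the fall or reverse it. Also open, from the compounds shown here alone, is how a carboxylic acid at the chain end would compare with the hydroxycarbamoyl end on this core.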